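The source may hold more compounds than are shown below. What is called first, only, known or untested is meant among the compounds shown, and "the series" means these compounds.

Measured compounds:
- compound 1, `Cn1c(=S)n(Cc2ccccc2C#N)c2c(N3CCC[C@@H](N)C3)ccnc21` — > 100000 nM
- compound 2, `Cn1c(=O)n(Cc2ccccc2C#N)c2c(N3CCC[C@@H](N)C3)cccc21` — > 100000 nM
- compound 3, `Cn1c(=O)n(Cc2ccccc2C#N)c2c(N3CC[C@@H](N)C3)ccnc21` — > 100000 nM

In an assay on isolated protein for inhibition of Dipeptidyl peptidase 9 (Homo sapiens), read by luminescence, with a stated time of 15 min (on this read-out lower numbers stand for stronger inhibition and higher numbers for weaker inhibition), compound 1 gives only a limit, > 100000 nM. In this assay compound 2 likewise reaches only a limit, > 100000 nM. In this assay compound 3 also stops at a limit, > 100000 nM. Within the data shown here, compound 3 therefore stands where every other measured compound stands: at the limit of > 100000 nM in this assay, at which 3 of the 3 values shown sit, so no ordering among the three is possible, and no step between measured compounds can be sized.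

Compound 4, `CC(=O)N[C@@H]1CCCN(c2ccnc3c2n(Cc2ccccc2C#N)c(=O)n3C)C1`, differs from compound 3 by 3-acetamidopiperidin-1-yl in place of 3-aminopyrrolidin-1-yl on an aromatic carbon. Among the measured compounds shown here, no measured step shows what this change does, and no measured compound resembles compound 4 closely enough to anchor the expectation. Given that compound 3 yields only a limit, > 100000 nM, the expected step from compound 3 to compound 4 in this assay is a number no higher from compound 3 to compound 4 (the limit leaves the size open), which is most likely no change beyond the scatter, with a modest chance of a measurable value appearing. Compound 4 is thus estimated at 100000 nM, within 20000 nM to 300000 nM.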

Compound 4, half-maximal inhibitory concentration: > 100000 nM
Compound 4: a limit, no number (the forecaster's own chance of this, stated with the estimate: 70%); the middle value lies on the limit itself.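

Compound 4 ends at a limit, as compound 3 does, so no step from compound 3 to compound 4 can be read in this assay, and all the compounds shown stand together: the limit of > 100000 nM in this assay, at which 4 of the 4 values shown sit.

The compounds shown leave open whether swapping 3-aminopyrrolidin-1-yl for 3-acetamidopiperidin-1-yl changes inhibition at all in this assay.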